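A few compounds are considered here, and "the series" means these few. Any claim that something is new, unique, unknown or untested is made for them only; others in the source may bear on it.

Within the data shown here, compound 2 `CC(C)=CCOc1ccccc1C1CC(=O)c2ccccc2O1` gives 40.3% in a functional assay on J774.A1 cells (Mus musculus) for inhibition, read by immunoassay, with a stated time of 12 h, tested at 30 uM (on this read-out lower numbers stand for less inhibition and higher numbers for more inhibition at the one concentration tested (going by the name of the read-out)), one of only two numbers measured so far. Compound 1 `CC(C)COc1ccccc1C1CC(=O)c2ccccc2O1` gives 33.5% in this assay, and the step of a number 6.8 percentage points higher from compound 1 to compound 2 (within the scatter) stays within the scatter. Compound 3 `CCCCOc1ccccc1C1CC(=O)c2ccccc2O1` is not yet tested; its change from compound 2 is propyl in place of 2-methylprop-1-en-1-yl on a saturated chain carbon bound to an oxygen on an aromatic ring. Among the measured compounds shown here, the single measured step, a number 6.8 percentage points higher from compound 1 to compound 2 (within the scatter), also swapped the group at this same place and did not move beyond the scatter, so the expected step is a number 3.3 percentage points lower from compound 2 to compound 3 (within the scatter), nothing beyond the scatter. Compound 3 is therefore estimated to give 37% in this assay, within 22% to 52%.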

Compound 3, a percentage reported as inhibition, at one concentration (the size of the read-out at that concentration, not a potency): 42.5%
Compound 3: the middle estimate sits 5.5 percentage points below what was measured; measured number inside the range.
By their numbers in this assay, from the lowest: compounds 1, 2 and 3 (each within the scatter of the next).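

In this assay, propyl at this place, on a saturated chain carbon bound to an oxygen on an aromatic ring, keeps the number within the scatter of both earlier groups: a number 2.2 percentage points higher from compound 2 to compound 3 (within the scatter), and a number 9 percentage points higher from compound 1 to compound 3 (within the scatter). The double bond that leaves with 2-methylprop-1-en-1-yl is thus not needed to hold the number at this level. No other measurement here bears on this result. As far as these compounds go, whether a longer chain, an amine or a carboxylic acid at this place would move the number beyond the scatter remains open, as do changes elsewhere on the shared core.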